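This account rests on a few compounds, and the source may have more. Where it says the series, first, only, none or still open, it means among the compounds named here.

The measured compounds:

compound 1, `COc1ccc2c(=O)c(/C=C/C(=O)Nc3cccc(Cl)c3)coc2c1`: in a functional assay on HeLa cells (Homo sapiens) for inhibition, read by MTT assay, with a stated time of 48 h (on this read-out higher numbers stand for weaker inhibition and lower numbers for stronger inhibition), compound 1 gives 11900 nM
compound 2, `CCOc1ccc(NC(=O)/C=C/c2coc3cc(OC)ccc3c2=O)cc1`: compound 2 reaches only the limit of this assay, > 100000 nM
compound 3, `COc1ccc2c(=O)c(/C=C/C(=O)Nc3ccccc3OC)coc2c1`: compound 3 likewise sits at the limit, > 100000 nM

Compound 1 is the only one of the three for which this assay returns a number; the other two values are limits. Compound 4, `COc1ccc2c(=O)c(/C=C/C(=O)Nc3ccccc3Cl)coc2c1`, differs from compound 1 in one place: 2-chlorophenyl in place of 3-chlorophenyl on an amide-type nitrogen.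

Among the measured compounds shown here, two measured steps bear on this change, both starting from compound 1 and both altering the aryl group on the amide-type nitrogen. The step of an at least 8.4-fold higher number from compound 1 to compound 2 (0.92 log units; beyond the scatter) and the step of an at least 8.4-fold higher number from compound 1 to compound 3 (0.92 log units; beyond the scatter) each weaken inhibition, and their size is bounded by the limit of > 100000 nM in this assay, at which 2 of the 3 values shown sit. The step that the two limits leave unreadable from compound 2 to compound 3 cannot be read. Neither step keeps the chlorine; the 2-methoxyphenyl of compound 3 is the nearer analogue, and it ends at the limit. Compound 4 is therefore expected to show weaker inhibition than compound 1, with the step of a 3.8-fold higher number from compound 1 to compound 4 (0.58 log units; beyond the scatter) estimated as modest to large. The estimate for compound 4 in this assay is 45000 nM, expected to lie between 12000 nM and 150000 nM, with a real chance that only a limit is reported.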

Compound 4, half-maximal inhibitory concentration: 22400 nM
For compound 4 the middle estimate is 2.0-fold (0.30 log units) above the measured one, and the stated range covers the measured number.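

In this assay, 2-chlorophenyl in place of 3-chlorophenyl on the amide-type nitrogen gives a 1.9-fold higher number from compound 1 to compound 4 (0.27 log units; within the scatter), so the two chlorophenyl groups are not told apart here and a change of aryl group in this place need not end at the limit. Chloro in place of methoxy on an aromatic carbon gives an at least 4.4-fold lower number from compound 3 to compound 4 (0.64 log units; beyond the scatter), and 2-chlorophenyl in place of 4-ethoxyphenyl gives an at least 4.4-fold lower number from compound 2 to compound 4 (0.64 log units; beyond the scatter), so among these four compounds both chlorophenyl groups return a number and neither alkoxy-bearing phenyl group does. The true size of these two steps stays open-ended: the limit of > 100000 nM in this assay, at which 2 of the 4 values shown sit.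

As far as these compounds go, whether a number is also returned with 4-chlorophenyl on the amide-type nitrogen, or with bromine or a trifluoromethyl group in place of the chlorine, remains open. Also open, from the compounds shown here alone, is whether the alkoxy group itself or its place on the ring separates compound 2 and compound 3 from the chlorophenyl compounds, and the step between those two cannot be read.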